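Cyclopentyl in Place of Methyl: Estimating Compound 4

The source may report more compounds than this note shows. Statements on the series, on what has been measured and on what is new or still open speak of the compounds shown alone.

Compound 1 `CNc1nc(OC)nc2c1ncn2C1O[C@H](CO)[C@H](O[C@@H]2OC(CO)[C@H](OP(=O)(O)O)C(OP(=O)(O)O)[C@@H]2O)[C@@H]1OP(=O)(O)O`: 82 nM in a functional assay (Hepatocyte) with Rattus norvegicus as the target; a lower number here means that less compound is needed, a higher number that more compound is needed for the effect
Compound 2 `CNc1ncnc2c1ncn2C1O[C@H](CO)[C@H](O[C@@H]2OC(CO)[C@H](OP(=O)(O)O)C(OP(=O)(O)O)[C@@H]2O)[C@@H]1OP(=O)(O)O`: 13 nM
Compound 3 `O=P(O)(O)OC1[C@@H](OP(=O)(O)O)C(CO)O[C@@H](O[C@@H]2[C@H](OP(=O)(O)O)C(n3cnc4c(NC5CCCCC5)ncnc43)O[C@@H]2CO)[C@H]1O`: 25 nM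

Compound 2 gives the lowest of the three numbers in this assay. The step of a 6.3-fold lower number from compound 1 to compound 2 (0.80 log units; beyond the scatter) lies beyond the scatter, so compound 1 stands clearly apart, whereas the step of a 1.9-fold higher number from compound 2 to compound 3 (0.28 log units; within the scatter) lies within the scatter, so compound 2 and compound 3 cannot be told apart on these numbers.

Compound 4 `O=P(O)(O)OC1[C@@H](OP(=O)(O)O)C(CO)O[C@@H](O[C@@H]2[C@H](OP(=O)(O)O)C(n3cnc4c(NC5CCCC5)ncnc43)O[C@@H]2CO)[C@H]1O` differs from compound 2 by cyclopentyl in place of methyl on a nitrogen on an aromatic ring; cut one bond further out, the change reads methylamino to cyclopentylamino. The step that bears on it is a 1.9-fold higher number from compound 2 to compound 3 (0.28 log units; within the scatter), where cyclohexyl in place of methyl on a nitrogen on an aromatic ring left the number within the scatter. The step of a 6.3-fold lower number from compound 1 to compound 2 (0.80 log units; beyond the scatter) concerns a different place, hydrogen in place of methoxy on an aromatic carbon, and does not inform this change. A five-membered ring of carbon only on the same nitrogen is therefore expected to behave like the six-membered one, giving a 1.5-fold higher number from compound 2 to compound 4 (0.19 log units; within the scatter), no step beyond the scatter. Compound 4 is accordingly estimated at 20 nM, with a range from 8 nM to 50 nM.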

Compound 4, half-maximal effective concentration: 13 nM
Compound 4: the middle estimate sits 1.5-fold (0.19 log units) above what was measured; measured number inside the range.
By their numbers in this assay, from the lowest: compounds 2, 4 and 3 (each within the scatter of the next); then compound 1.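

In this assay the step of no change at the digits printed from compound 2 to compound 4 (within the scatter) joins the earlier cyclohexyl result, so a ring of carbon only on this nitrogen on an aromatic ring has now twice taken the place of methyl without leaving the scatter. For the compounds shown here, the step of a 1.9-fold lower number from compound 3 to compound 4 (0.28 log units; within the scatter) adds what the earlier compounds could not show: the five-membered and six-membered rings cannot be told apart at this position. Nothing at hand accounts for these numbers.

From the compounds shown here alone, whether the same holds for other groups on this nitrogen, such as a longer chain, a phenyl ring or a hydroxyethyl group, remains open. Also open, going by these compounds, is whether the step of a 6.3-fold lower number from compound 1 to compound 2 (0.80 log units; beyond the scatter) would recur in the same size with cyclopentyl on the nitrogen instead of methyl.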